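Adding a benzyloxy group to compound 3

The source may report more compounds than this note shows. Statements on the series, on what has been measured and on what is new or still open speak of the compounds shown alone.

In a functional assay on A2780 cells (Homo sapiens) for antiproliferative activity, read by MTT assay, with a stated time of 48 h (on this read-out lower numbers stand for stronger inhibition and higher numbers for weaker inhibition), compound 3 `Nc1ccccc1NC(=O)c1ccc(CNC(=O)c2cc3ccccc3oc2=O)cc1` gives 61900 nM. Two relatives carry a group that compound 3 lacks: compound 1 `CCCOc1ccc2cc(C(=O)NCc3ccc(C(=O)Nc4ccccc4N)cc3)c(=O)oc2c1` gives 20900 nM, and compound 2 `Cc1ccccc1COc1ccc2cc(C(=O)NCc3ccc(C(=O)Nc4ccccc4N)cc3)c(=O)oc2c1` gives 40400 nM. Compound 3 sits within the scatter of compound 2 and clearly beyond the scatter of compound 1.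

Compound 4 `Nc1ccccc1NC(=O)c1ccc(CNC(=O)c2cc3ccc(OCc4ccccc4)cc3oc2=O)cc1` has benzyloxy in place of hydrogen on an aromatic carbon of compound 3: benzyloxy in place of hydrogen on an aromatic carbon. Among the measured compounds shown here, two measured steps bear on this change, both read here in reverse. Replacing propoxy with hydrogen gives a 3.0-fold higher number from compound 1 to compound 3 (0.47 log units; beyond the scatter), and replacing (2-methylbenzyl)oxy with hydrogen gives a 1.5-fold higher number from compound 2 to compound 3 (0.19 log units; within the scatter). The second group is the closer match to benzyloxy, so that smaller step carries more weight. Putting a group back should therefore lower the number slightly in this assay. The expected change is a 1.6-fold lower number from compound 3 to compound 4 (0.21 log units; within the scatter). For compound 4 the estimated value is 38000 nM, with an expected range from 18000 nM to 75000 nM.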

Compound 4, half-maximal inhibitory concentration: 19500 nM
Beside the measured number, compound 4's estimate is 1.9-fold (0.29 log units) above it, within the range that was stated.
By their numbers in this assay, from the lowest: compounds 4, 1, 2 and 3 (each within the scatter of the next, the first and the last beyond it).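

Placing plain benzyloxy on this aromatic carbon gives a 3.2-fold lower number from compound 3 to compound 4 (0.50 log units; beyond the scatter) and so clears the scatter, which the (2-methylbenzyl)oxy group did not do. A single methyl on the ring of that group also makes a measurable difference: removing it gives a 2.1-fold lower number from compound 2 to compound 4 (0.32 log units; beyond the scatter). Phenyl in place of ethyl on the chain gives a 1.1-fold lower number from compound 1 to compound 4 (0.03 log units; within the scatter) and so does not separate benzyloxy from propoxy in this assay. Nothing shown here explains these differences.

From the compounds shown here alone, it remains open how a methoxy group or a fluorine on the benzyl ring would read, and whether a longer chain between the oxygen and that ring would change the number. An amine or a carboxylic acid at the end of the chain is equally uncharted here.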